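The compounds below may be only part of what the source reports. "The series", "measured", "known", "first", "only" and "open" are said of these compounds alone.

Measured so far in a functional assay on SH-SY5Y cells (Homo sapiens) for antiproliferative activity, read by MTT assay, with a stated time of 72 h; a lower number here means a stronger inhibitor, a higher number a weaker inhibitor:
compound 1 `COc1cc2c(Nc3ccc(C#N)cc3)ncnc2cc1OCCCN1CCCCC1` — compound 1 gives 18800 nM
compound 2 `COc1cc2c(Nc3ccc(C#N)cc3)ncnc2cc1OCCCN1CCC(CO)CC1` — compound 2 gives 21600 nM
compound 3 `COc1cc2c(Nc3ccc(C#N)cc3)ncnc2cc1OCCCN1CCCCC1CCO` — compound 3 gives > 100000 nM, a limit of the assay and not a number

Compound 1 and compound 2 give numbers within the scatter of each other, so neither is placed ahead of the other; the third value is a limit, as recorded in the limit of > 100000 nM in this assay, at which 1 of the 3 values shown sits.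

Compound 4 `COc1cc2c(Nc3ccc(C#N)cc3)ncnc2cc1OCCCN1CCC(c2ccccc2)CC1` is not yet measured. It differs from compound 1 by phenyl in place of hydrogen on a saturated ring carbon.

Among the measured compounds shown here, two measured steps bear on it. Hydroxymethyl on the same saturated ring carbon gave a 1.1-fold higher number from compound 1 to compound 2 (0.06 log units; within the scatter). 2-Hydroxyethyl on a different saturated ring carbon gave an at least 5.3-fold higher number from compound 1 to compound 3 (0.72 log units; beyond the scatter), and the same contrast appears in an at least 4.6-fold higher number from compound 2 to compound 3 (0.66 log units; beyond the scatter). For the measured compounds named here, the only step beyond the scatter comes with a different position and group than the one now changed; at the position changed here, substitution gave no step beyond the scatter.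

Compound 4 is therefore expected to sit close to compound 1 in this assay, with a 1.6-fold lower number from compound 1 to compound 4 (0.19 log units; within the scatter) as the estimated step. The estimate for compound 4 is 12000 nM, between 4000 nM and 36000 nM.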

Compound 4, half-maximal inhibitory concentration: 7770 nM
For compound 4 the middle estimate is 1.5-fold (0.19 log units) above the measured one; the range from low to high includes it.
By their numbers in this assay, from the lowest: compound 4; then compounds 1 and 2 (each within the scatter of the next). At a limit, above all of these: compound 3.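

In this assay, among the compounds shown here, phenyl on the saturated ring carbon three ring bonds from the ring nitrogen gives the first step beyond the scatter at this position, with a 2.4-fold lower number from compound 1 to compound 4 (0.38 log units; beyond the scatter) as its size. Hydroxymethyl on that carbon gave no such step, and exchanging it for phenyl gives a 2.8-fold lower number from compound 2 to compound 4 (0.44 log units; beyond the scatter), so the number at this position does depend on the group placed there. The step of an at least 12-fold lower number from compound 3 to compound 4 (1.10 log units; beyond the scatter) is a bound only; compound 3 stands at a limit and not a number: the limit of > 100000 nM in this assay, at which 1 of the 4 values shown sits.

Whether the lower number belongs to an aromatic ring as such stays open, with phenyl and hydroxymethyl the only groups shown on this carbon; a benzyl group, a pyridin-4-yl ring or an aminomethyl group there would test it. Also open, going by these compounds, is whether phenyl behaves alike on the ring carbon that bears 2-hydroxyethyl in compound 3.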